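Notes on the step from compound 3 to compound 4

The compounds below may be only part of what the source reports. "The series", "measured", "known", "first", "only" and "open" are said of these compounds alone.

In a functional assay on NCI-H1975 cells (Homo sapiens) for cytotoxicity, read by MTT assay, with a stated time of 72 h (a lower number here means a stronger inhibitor, a higher number a weaker inhibitor), compound 1 `O=C(N/N=C/c1ccc(Br)cc1)N1CCc2ncnc(Nc3ccc(F)c(Cl)c3)c2C1` gives only a limit, > 200000 nM.

Compound 2 `O=C(N/N=C/c1cc(F)c(F)cc1Cl)N1CCc2ncnc(Nc3ccc(F)c(Cl)c3)c2C1` gives 46100 nM and compound 3 `O=C(N/N=C/c1cccs1)N1CCc2ncnc(Nc3ccc(F)c(Cl)c3)c2C1` gives 33000 nM. Going by the values given here, the gap, a 1.4-fold lower number from compound 2 to compound 3 (0.15 log units; within the scatter), leaves the two level, so these are the only two numbers and neither stands apart. Against the limit, the changes run as an at least 4.3-fold lower number from compound 1 to compound 2 (0.63 log units; beyond the scatter) and an at least 6.0-fold lower number from compound 1 to compound 3 (0.78 log units; beyond the scatter). All three steps change only the group on the carbon with a double bond to nitrogen.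

Compound 4 `O=C(N/N=C/c1cccs1)N1CCc2ncnc(Nc3cccc(C(F)(F)F)c3)c2C1` keeps the thiophen-2-yl of compound 3 and changes another place: 3-(trifluoromethyl)phenyl in place of 3-chloro-4-fluorophenyl on a nitrogen on an aromatic ring. Among the compounds with values here, no measured step touches that place, so the evidence is indirect. The nearest guide is a 1.4-fold lower number from compound 2 to compound 3 (0.15 log units; within the scatter), while an at least 6.0-fold lower number from compound 1 to compound 3 (0.78 log units; beyond the scatter) shows that larger moves occur in this series. No step beyond the scatter is expected, in either direction. The expected step is a 1.2-fold higher number from compound 3 to compound 4 (0.08 log units; within the scatter). For compound 4 the estimate is 40000 nM, with an expected range from 14000 nM to 120000 nM.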

Compound 4, half-maximal inhibitory concentration: 169000 nM
The estimate for compound 4 lay 4.2-fold (0.63 log units) below the measured number, outside the stated range (above it).
By their numbers in this assay, from the lowest: compounds 3 and 2 (each within the scatter of the next); then compound 4. At a limit, above all of these: compound 1.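

Going by these compounds alone, the group on the nitrogen on an aromatic ring can also shift the number beyond the scatter, whereas the earlier steps changed only the group on the carbon with a double bond to nitrogen: in this assay, 3-(trifluoromethyl)phenyl in place of 3-chloro-4-fluorophenyl, with thiophen-2-yl held constant, gives a 5.1-fold higher number from compound 3 to compound 4 (0.71 log units; beyond the scatter). This single step removes chlorine and fluorine and brings in trifluoromethyl together, so the separate parts of the change cannot be told apart. Compound 1 remains the only limit in the series: the limit of > 200000 nM in this assay, at which 1 of the 4 values shown sits.

On these data alone, whether this step carries over when 2-chloro-4,5-difluorophenyl or another group sits on the carbon with a double bond to nitrogen remains open. Also open, as far as these compounds go, is how a ring bearing a nitrile or a methoxy group, or a saturated amine in place of the aromatic ring, would behave on this nitrogen.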